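Swapping an allyl for a cyclopropyl on an aminoquinazoline

This account rests on a few compounds, and the source may have more. Where it says the series, first, only, none or still open, it means among the compounds named here.

Compound 1 `C=CCNc1nc(NCc2ccc(C(=O)Nc3ccc(F)cc3)cc2)c2ccccc2n1` is the starting point. Within the data shown here, in a functional assay on HCT-116 cells (Homo sapiens) for inhibition, read by luminescence and resazurin assay, with a stated time of 3 days (a lower number here means a stronger inhibitor, a higher number a weaker inhibitor), compound 1 gives 14000 nM, the highest of the three numbers measured so far. Compound 2 `C=CCNc1nc(NCc2ccc(C(=O)Nc3ccc(F)cc3)cc2)c2cc(C)ccc2n1`, which carries a methyl in place of a hydrogen on an aromatic carbon of the shared core, gives 13000 nM, and the step of a 1.1-fold lower number from compound 1 to compound 2 (0.03 log units; within the scatter). Among the measured compounds shown here, compound 3 `CNc1nc(NCc2ccc(NS(=O)(=O)c3ccc(C)cc3)cc2)c2ccccc2n1`, built on a different pattern of substituents, gives 5800 nM, which is the lowest of the three; no single-point step connects it to compound 1.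

Compound 4 `O=C(Nc1ccc(F)cc1)c1ccc(CNc2nc(NC3CC3)nc3ccccc23)cc1` differs from compound 1 by cyclopropyl in place of allyl on a nitrogen on an aromatic ring. For the measured compounds named here, none of the measured steps concerns this position: the only measured step changes an aromatic carbon elsewhere, and it stayed within the scatter. The change from allyl to cyclopropyl keeps the same count of heavy atoms and adds no donors or acceptors, so nothing in the data argues for a shift. For compound 4 the expected outcome is therefore a step of about a 1.2-fold lower number from compound 1 to compound 4 (0.07 log units; within the scatter), that is, no change beyond the scatter. Compound 4 is estimated at 12000 nM, with a range from 5000 nM to 30000 nM.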

Compound 4, half-maximal inhibitory concentration: 2700 nM
Beside the measured number, compound 4's estimate is 4.4-fold (0.65 log units) above it, and the stated range ends above it.
By their numbers in this assay, from the lowest: compound 4; then compound 3; then compounds 2 and 1 (each within the scatter of the next).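

In this assay, among these compounds, the nitrogen on an aromatic ring proves to be a place where a small swap registers: cyclopropyl in place of allyl gives a 5.2-fold lower number from compound 1 to compound 4 (0.71 log units; beyond the scatter), whereas the only earlier step, at an aromatic carbon, stayed within the scatter. The two groups have the same count of heavy atoms and differ in that allyl has a double bond and cyclopropyl a three-membered ring, so a step of this size can arise without any change in those atom counts. No measurement at hand explains the step.

As far as these compounds go, a propyl chain or a cyclobutyl ring on this nitrogen would help separate losing the double bond from gaining the ring, and that remains open. Also open, from the compounds shown here alone, is whether the step would hold with the methyl that compound 2 carries on the shared core.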